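This account rests on a few compounds, and the source may have more. Where it says the series, first, only, none or still open, it means among the compounds named here.

Measured so far:
Compound 1 `FC(F)(F)c1ccccc1NC(=S)N/N=C/c1ccc2ccccc2n1`: 18800 nM
Compound 2 `S=C(NCc1ccccc1)N/N=C/c1ccc2ccccc2n1`: 62800 nM

Both were read in a functional assay on HeLa cells (Homo sapiens) for antiproliferative activity, read by sulforhodamine B assay, with a stated time of 72 h; on this read-out lower numbers stand for stronger inhibition and higher numbers for weaker inhibition. Compound 2 stands highest of the two numbers with 62800 nM; the nearest is compound 1, whose 18800 nM lies beyond the scatter below it. Compound 3 `COc1ccc(NC(=S)N/N=C/c2ccc3ccccc3n2)cc1` is not yet measured. It differs from compound 2 by 4-methoxyphenyl in place of benzyl on an amide-type nitrogen. Among the measured compounds shown here, no step between measured compounds covers this change, so only the two values are known. Compound 1 carries a ring on that nitrogen and gives the lower number. The step expected is a 3.1-fold lower number from compound 2 to compound 3 (0.50 log units; beyond the scatter), downward and beyond the scatter. Compound 3 is estimated at 20000 nM, range 6000 nM to 60000 nM.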

Compound 3, half-maximal inhibitory concentration: 72600 nM
For compound 3 the middle estimate is 3.6-fold (0.56 log units) below the measured one; measured number above the stated range.
By their numbers in this assay, from the lowest: compound 1; then compounds 2 and 3 (each within the scatter of the next).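

In this assay, 4-methoxyphenyl in place of benzyl on the amide-type nitrogen gives a 1.2-fold higher number from compound 2 to compound 3 (0.06 log units; within the scatter), so this exchange leaves the number unmoved. Having a phenyl-type group on that nitrogen is therefore not enough to reach the lower number: compound 3 reads 72600 nM, while compound 1 reads 18800 nM, and the group itself matters. No measured evidence accounts for this result. Still open, going by these compounds, is whether a longer chain or an amine on that nitrogen would move the number beyond the scatter.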